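This account rests on a few compounds, and the source may have more. Where it says the series, first, only, none or still open, it means among the compounds named here.

Of the compounds shown here, three of one series have been measured in a functional assay on HepG2 cells (Homo sapiens) for antiproliferative activity, read by CCK-8 assay, with a stated time of 72 h; on this read-out higher numbers stand for weaker inhibition and lower numbers for stronger inhibition. Compound 1 `O=C(Nc1cccc(-c2oc3cc(-c4ccc(F)cc4)ccc3c(=O)c2O)c1)c1ccccc1F` gives 10100 nM. Compound 2 `O=C(Nc1cccc(-c2oc3cc(-c4ccc(F)cc4)ccc3c(=O)c2O)c1)c1ccc(F)cc1` gives 9280 nM. Compound 3 `CCc1ccc(C(=O)Nc2cccc(-c3oc4cc(-c5ccc(F)cc5)ccc4c(=O)c3O)c2)cc1` gives 20600 nM, the highest of the three numbers; the gap to the nearest one is a 2.0-fold higher number from compound 1 to compound 3 (0.31 log units; beyond the scatter), and the gap to the furthest is a 2.2-fold higher number from compound 2 to compound 3 (0.35 log units; beyond the scatter). The step between compound 1 and compound 2 is a 1.1-fold lower number from compound 1 to compound 2 (0.04 log units; within the scatter).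

Compound 4 `O=C(Nc1cccc(-c2oc3cc(-c4ccc(F)cc4)ccc3c(=O)c2O)c1)c1ccc(Cl)nc1` has not been measured. It differs from compound 3 by 6-chloropyridin-3-yl in place of 4-ethylphenyl on a carbonyl carbon. For the measured compounds named here, none of the measured steps changes the ring itself to one with a hetero atom; the two steps that lead to compound 3 only show that ethyl in place of fluoro raised the number modestly, and the step from compound 1 to compound 2 shows that moving fluoro left the number within the scatter. The expectation for compound 4 is therefore loose, an estimated step of a 1.7-fold lower number from compound 3 to compound 4 (0.23 log units; within the scatter) in this assay with no firm direction. Compound 4 is estimated at 12000 nM, in a range from 5000 nM to 30000 nM.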

Compound 4, half-maximal inhibitory concentration: 4610 nM
For compound 4 the middle estimate is 2.6-fold (0.42 log units) above the measured one, outside the stated range (below it).
By their numbers in this assay, from the lowest: compounds 4, 2 and 1 (each within the scatter of the next, the first and the last beyond it); then compound 3.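

For the compounds shown here, at this position, on a carbonyl carbon whose other neighbour is an amide-type nitrogen, 6-chloropyridin-3-yl is the first ring with a hetero atom, and in this assay replacing 4-ethylphenyl with it gives a 4.5-fold lower number from compound 3 to compound 4 (0.65 log units; beyond the scatter). The same ring also gives a 2.2-fold lower number from compound 1 to compound 4 (0.34 log units; beyond the scatter), whereas a 2.0-fold lower number from compound 2 to compound 4 (0.30 log units; within the scatter), so a ring with a hetero atom and a chlorine is accepted here without the number rising, though it is not separated from every carbon-only ring. No evidence is available to explain these steps.

From the compounds shown here alone, the ring nitrogen and the chlorine enter together, and what each contributes stays open; a plain pyridin-3-yl or a 4-chlorophenyl group at this place would separate the two. Going by these compounds, how a 6-aminopyridin-3-yl group would read here is also open.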